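Tetrabrominated core: side-chain hydroxyl change from compound 3

The source may hold more compounds than are shown below. What is called first, only, known or untested is meant among the compounds shown, and "the series" means these compounds.

Compound 1 `C[C@@H](O)CCn1nc2c(Br)c(Br)c(Br)c(Br)c2n1` gives 18% in a functional assay on MCF7 cells (Homo sapiens) for antiproliferative activity, read by MTT assay, with a stated time of 24 h, tested at 100 uM; on this read-out higher numbers stand for a weaker effect at the one concentration tested and lower numbers for a stronger effect. Compound 2 `C[C@H](O)CCn1nc2c(Br)c(Br)c(Br)c(Br)c2n1` gives 31%, and compound 3 `CC(O)CCn1nc2c(Br)c(Br)c(Br)c(Br)c2n1` gives 57%, the highest of the three numbers and so the weakest effect at the single concentration. The measured steps are a number 13 percentage points higher from compound 1 to compound 2 (beyond the scatter), a number 39 percentage points higher from compound 1 to compound 3 (beyond the scatter) and a number 26 percentage points higher from compound 2 to compound 3 (beyond the scatter); each turns on configuration alone, as the fact that compounds 1 and 2 differ only in the configuration as drawn, the fact that one of compounds 1 and 3 is drawn with a defined configuration and the other without, at the place where they differ and the fact that one of compounds 2 and 3 is drawn with a defined configuration and the other without, at the place where they differ show. Compound 4 `OCC(O)Cn1nc2c(Br)c(Br)c(Br)c(Br)c2n1` differs from compound 3 by 1,2-dihydroxyethyl in place of 2-hydroxypropyl on a saturated chain carbon bound to an aromatic nitrogen. Going by the values given here, no measured step alters the atoms of the chain, so none bears on this change and no direction can be read from them. The expected step is no change at the digits printed from compound 3 to compound 4 (within the scatter), with no clear direction. Compound 4 is expected to give 57%, in a range from 25% to 85%.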

Compound 4, a percentage reported as activity, at one concentration (the size of the read-out at that concentration, not a potency): 53%
For compound 4 the middle estimate is 4 percentage points above the measured one; measured number inside the range.
By their numbers in this assay, from the lowest: compound 1; then compound 2; then compounds 4 and 3 (each within the scatter of the next).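

In this assay the only change of chain atoms shown gives a number 4 percentage points lower from compound 3 to compound 4 (within the scatter) and so does not separate 1,2-dihydroxyethyl from 2-hydroxypropyl on a saturated chain carbon bound to an aromatic nitrogen. Compound 4, drawn without a configuration, stands apart from the two configurationally defined compounds, with a number 22 percentage points higher from compound 2 to compound 4 (beyond the scatter) and a number 35 percentage points higher from compound 1 to compound 4 (beyond the scatter) on record. No fact at hand accounts for the effect of this chain change. Going by these compounds alone, the single configurations of compound 4 remain open. Also open, from the compounds shown here alone, is whether an amine, a carboxylic acid or a longer chain at this position would shift the number.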